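The source may hold more compounds than are shown below. What is called first, only, known or untested is meant among the compounds shown, and "the series" means these compounds.

Measured so far:
compound 1 `O=C(COCc1ccccc1)N1CCN(c2ccccn2)CC1`, 5400 nM
compound 2 `O=C(COCc1ccccc1)N1CCN(c2ccccc2Cl)CC1`, 820 nM
compound 3 `N#Cc1cccnc1N1CCN(C(=O)COCc2ccccc2)CC1`, > 10000 nM

In a functional assay on HEK293 cells for positive allosteric modulation of metabotropic glutamate receptor 5 (Rattus norvegicus), read by fluorescence and calcium flux (on this read-out higher numbers stand for an effect only at larger amounts of compound and lower numbers for an effect already at smaller amounts), compound 3 gives > 10000 nM, which is a limit of the assay and not a number. It therefore sits at the limit of > 10000 nM in this assay, at which 1 of the 3 values shown sits. The step of an at least 12-fold higher number from compound 2 to compound 3 (1.08 log units; beyond the scatter) is large, whereas the step of an at least 1.8-fold higher number from compound 1 to compound 3 (0.26 log units; that floor lies within the scatter) has a floor within the scatter, so compound 3 and compound 1 cannot be ordered on these numbers.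

Compound 4 `O=C(COCc1ccccc1)N1CCN(c2nccs2)CC1` differs from compound 3 in one place: 1,3-thiazol-2-yl in place of 3-cyanopyridin-2-yl on an amine nitrogen in a ring. Going by the values given here, the change undoes the cyano addition seen in the step of an at least 1.8-fold higher number from compound 1 to compound 3 (0.26 log units; that floor lies within the scatter), which was within the scatter, and at the same time replaces the six-membered ring by a five-membered one, for which no measured step exists. The step of a 6.6-fold lower number from compound 1 to compound 2 (0.82 log units; beyond the scatter) shows that the group on this ring nitrogen can shift the number modestly, but only for a 2-chlorophenyl.

The expectation for compound 4 is therefore a number near that of compound 1 rather than a limit, and the step of an at least 1.6-fold lower number from compound 3 to compound 4 (0.22 log units; that floor lies within the scatter) is expected to be a lowering of the number. Compound 4 is estimated at 6000 nM, with a range from 2000 nM to 20000 nM.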

Compound 4, half-maximal effective concentration: > 10000 nM
Compound 4: only a limit was reported; the forecaster's own chance of this, stated with the estimate: 30%; at least 1.6-fold (0.22 log units) between middle value and limit.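

In this assay compound 4 gives > 10000 nM, which is a limit of the assay and not a number, and it is the second compound here to end at that limit: the limit of > 10000 nM in this assay, at which 2 of the 4 values shown sit.

Putting 1,3-thiazol-2-yl in place of 2-chlorophenyl on the amine nitrogen in the ring gives an at least 12-fold higher number from compound 2 to compound 4 (1.08 log units; beyond the scatter), so this five-membered aromatic ring does not keep the lower number seen with the 2-chlorophenyl of compound 2. Against pyridin-2-yl, the same position gives an at least 1.8-fold higher number from compound 1 to compound 4 (0.26 log units; that floor lies within the scatter); that floor lies within the scatter, so compound 1 and compound 4 cannot be ordered, and the step between compound 3 and compound 4 cannot be read at all, as both values are limits.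

The compounds shown leave open how a plain phenyl or a 2-methylphenyl on this nitrogen would read, and such groups could tell whether the benzene ring or its chlorine goes with the lower number of compound 2. Also open, on these data alone, is where compound 3 and compound 4 truly lie beyond their limits, so 3-cyanopyridin-2-yl and 1,3-thiazol-2-yl cannot be ranked against each other.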